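Chain extension on the amide of the shared core

The compounds below may be only part of what the source reports. "The series", "measured", "known", "first", "only" and "open" are said of these compounds alone.

Measured so far:
compound 1, `CCCc1nc2c(C)cc(C(=O)Nc3ccc(C)cc3)cc2n1Cc1ccc(-c2ccccc2C(=O)O)cc1`, 61 nM
compound 2, `CCCc1nc2c(C)cc(NC(=O)CC)cc2n1Cc1ccc(-c2ccccc2C(=O)O)cc1`, 78 nM

In an assay on isolated protein for displacement of a labelled ligand from Type-2 angiotensin II receptor (Homo sapiens), with a stated time of 180 min (on this read-out lower numbers stand for stronger inhibition and higher numbers for weaker inhibition), compound 1 gives 61 nM and compound 2 gives 78 nM. For the measured compounds named here, the two numbers sit within the scatter of each other: the single step, a 1.3-fold higher number from compound 1 to compound 2 (0.11 log units; within the scatter), does not separate them, so compound 2 cannot be placed above or below compound 1 on this read-out.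

Compound 3, `CCCC(=O)Nc1cc(C)c2nc(CCC)n(Cc3ccc(-c4ccccc4C(=O)O)cc3)c2c1`, differs from compound 2 by methyl in place of hydrogen on a saturated chain carbon, two bonds along the chain from a carbonyl carbon; read one bond further out, propanoyl becomes propylcarbonyl. Going by the values given here, no measured step touches this kind of change: the only step in hand exchanges the whole group on the aromatic carbon and is itself within the scatter. With nothing pointing in either direction, no movement beyond the scatter is expected, and compound 3 is estimated at 70 nM, range 30 nM to 160 nM, a step of a 1.1-fold lower number from compound 2 to compound 3 (0.05 log units; within the scatter).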

Compound 3, half-maximal inhibitory concentration: 53 nM
Beside the measured number, compound 3's estimate is 1.3-fold (0.12 log units) above it; the measured number falls inside the stated range.
By their numbers in this assay, from the lowest: compounds 3, 1 and 2 (each within the scatter of the next).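

In this assay, for the compounds shown here, methyl in place of hydrogen on the saturated chain carbon, two bonds along the chain from a carbonyl carbon, gives a 1.5-fold lower number from compound 2 to compound 3 (0.17 log units; within the scatter) and so adds a first step on the chain itself, one that does not separate the two compounds. Exchanging the whole group on the aromatic carbon gives a 1.2-fold lower number from compound 1 to compound 3 (0.06 log units; within the scatter) as well, so (propylcarbonyl)amino, like propanoylamino, cannot be told apart from (4-methylphenyl)carbamoyl on this read-out. No supporting data bear on this result.

On these data alone, whether a longer chain, a branched chain or a terminal amine on this amide would produce a step beyond the scatter remains open. So far, the shared core shows no readable response to changes at this position.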